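A few compounds are considered here, and "the series" means these few. Any claim that something is new, unique, unknown or untested is made for them only; others in the source may bear on it.

Compound 1 `COc1cc2ncnc(Nc3ccc(NC(=O)c4ccc(C(C)(C)C)cc4)cc3)c2cc1OC`: > 100000 nM
Compound 2 `COc1cc2ncnc(Nc3ccc(NC(=O)c4ccc(F)cc4)cc3)c2cc1OC`: 27000 nM

In a functional assay on MCF7 cells (Homo sapiens) for inhibition, read by MTT assay (a lower number here means a stronger inhibitor, a higher number a weaker inhibitor), compound 1 gives > 100000 nM, which is a limit and not a number. Going by the values given here, compound 2, at 27000 nM, therefore holds the only actual number so far. Compound 3 `COc1cc2ncnc(Nc3ccc(NC(=O)c4ccccc4Cl)cc3)c2cc1OC` differs from it as follows: 2-chlorophenyl in place of 4-fluorophenyl on a carbonyl carbon. Among the compounds with values here, only one measured step bears on this, an at least 3.7-fold lower number from compound 1 to compound 2 (0.56 log units; beyond the scatter), and it exchanged a different pair of groups, so it offers only a loose guide. The expected change, a 1.1-fold higher number from compound 2 to compound 3 (0.05 log units; within the scatter), lies within the scatter, with no clear direction in this assay. For compound 3 the estimated value is 30000 nM, with an expected range from 10000 nM to 90000 nM.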

Compound 3, half-maximal inhibitory concentration: 36000 nM
For compound 3 the middle estimate is 1.2-fold (0.08 log units) below the measured one, and the stated range covers the measured number.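

Exchanging 4-fluorophenyl for 2-chlorophenyl on the carbonyl carbon gives no clear shift in this assay, with a 1.3-fold higher number from compound 2 to compound 3 (0.12 log units; within the scatter). A second halogen-bearing phenyl group also stands apart from the 4-(tert-butyl)phenyl group, with an at least 2.7-fold lower number from compound 1 to compound 3 (0.44 log units; beyond the scatter). This comparison rests on a limit for compound 1, not a number: the limit of > 100000 nM in this assay, at which 1 of the 3 values shown sits.

The two halogen-bearing groups differ in both halogen and placement, so the contribution of each remains unresolved. From the compounds shown here alone, it also remains open how a 4-chlorophenyl group or an amine-bearing phenyl group would read here.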